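A Benzyl Group on the Hydroxy of Compound 2

The source may hold more compounds than are shown below. What is called first, only, known or untested is meant among the compounds shown, and "the series" means these compounds.

Measured compounds:
compound 1 `CNc1ccc(-c2cn3c(OC)cc(OC)nc3n2)cc1`: > 100000 nM
compound 2 `Cc1cc(O)n2cc(-c3ccc([N+](=O)[O-])cc3)nc2n1`: 38900 nM

In a functional assay on A549 cells (Homo sapiens) for antiproliferative activity, read by MTT assay, with a stated time of 72 h (on this read-out lower numbers stand for stronger inhibition of growth and higher numbers for weaker inhibition of growth), compound 1 returns only a limit, > 100000 nM. In this assay compound 2 gives 38900 nM, the only full number shown. The other entry, that of compound 1, is the limit described by the limit of > 100000 nM in this assay, at which 1 of the 2 values shown sits. Compound 2 therefore stands as the single point from which the next change can be judged.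

Compound 3 `Cc1cc(OCc2ccccc2)n2cc(-c3ccc([N+](=O)[O-])cc3)nc2n1` carries benzyl in place of hydrogen on an oxygen on an aromatic ring. The difference, read one bond further out, is hydroxy to benzyloxy on the shared core of compound 2. For the measured compounds named here, no step between two measured compounds is available to size this change, so the direction rests on the structural change alone.

Compound 3 is expected to shift by a 1.9-fold lower number from compound 2 to compound 3 (0.29 log units; within the scatter) in this assay, a step that may not clearly exceed the usual scatter. Compound 3 is estimated at 20000 nM in this assay, within 4000 nM to 100000 nM, with a real chance that only a limit is reported.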

Compound 3, concentration for 50% growth inhibition: 71000 nM
For compound 3 the middle estimate is 3.6-fold (0.55 log units) below the measured one; the range from low to high includes it.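

Placing benzyl on the oxygen gives the first sized step for this position: in this assay, hydroxy to benzyloxy reads as a 1.8-fold higher number from compound 2 to compound 3 (0.26 log units; within the scatter). For the compounds shown here, the earlier compounds offered no step at all, so this is the first sign that this position can carry the added benzyl, with its six-membered aromatic ring of carbon only, without a step that stands clear of the usual scatter. This one pair gives no reason for that outcome, and nothing measured here bears on one.

The compounds shown leave open how this oxygen would read with a smaller group such as methyl, with a longer chain ending in an amine or a carboxylic acid, or with a benzyl that itself carries a substituent such as fluorine, and whether any of these would give a step beyond the scatter. On these data alone, it also remains open whether hydroxy to benzyloxy would read the same way in other assays or on other cores, as this single step, taken on one core and in one cell line, cannot settle either point.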